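Cyanoguanidine tail variation on a shared pyridazinone core

The source may hold more compounds than are shown below. What is called first, only, known or untested is meant among the compounds shown, and "the series" means these compounds.

Compound 3 `N#CNC(=N)NCCCCCCn1nc(-c2ccccc2)ccc1=O` gives 20.5% in a functional assay on the whole organism with Rattus norvegicus as the target, at a dose of 100 mg/kg (a higher number here means more inhibition at the dose given (going by the name of the read-out), a lower number less inhibition), the smallest of the three numbers, though its steps to the others lie within the scatter: a number 7 percentage points lower from compound 1 to compound 3 (within the scatter) and a number 8.6 percentage points lower from compound 2 to compound 3 (within the scatter). Compound 1 `CCC/N=C(/NC#N)NCCCCCn1nc(-c2ccccc2)ccc1=O` gives 27.5% and compound 2 `CC/N=C(/NC#N)NCCCCCCn1nc(-c2ccccc2)ccc1=O` gives 29.1%; between them a number 1.6 percentage points higher from compound 1 to compound 2 (within the scatter). Compound 4 `CN(C)/C(=N/CCCCCCn1nc(-c2ccccc2)ccc1=O)NC#N` differs from compound 3 by a group of 8 heavy atoms (4 carbon, 4 nitrogen; no ring) in place of a group of 6 heavy atoms (2 carbon, 4 nitrogen; no ring), on a saturated chain carbon, six bonds along the chain from an aromatic nitrogen. Both earlier replacements of the tail group, from compound 1 to compound 3 and from compound 2 to compound 3, stayed within the scatter, so no step beyond the scatter is expected here either. Compound 4 is therefore estimated at 26%, within 12% to 40%, an expected step of a number 5.5 percentage points higher from compound 3 to compound 4 (within the scatter).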

Compound 4, a percentage reported as inhibition, in the whole organism at one dose (the size of the read-out at that dose, not a potency): 58.4%
Compound 4: the middle estimate sits 32.4 percentage points below what was measured; measured number outside the range, above it.
By their numbers in this assay, from the lowest: compounds 3, 1 and 2 (each within the scatter of the next); then compound 4.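

In this assay, among the compounds shown here, the tail group is the first change here to move the number beyond the scatter: the swap on the saturated chain carbon, six bonds along the chain from an aromatic nitrogen, gives a number 37.9 percentage points higher from compound 3 to compound 4 (beyond the scatter) and the other group of 8 heavy atoms at that place gives a number 29.3 percentage points higher from compound 2 to compound 4 (beyond the scatter) while the comparison with the five-bond chain gives a number 30.9 percentage points higher from compound 1 to compound 4 (beyond the scatter) and so sets compound 4 apart from all three earlier compounds. Nothing measured here bears on why this tail stands apart.

On these data alone, whether a diethylamino group, a pyrrolidine or a longer chain in this tail would keep the higher number stays open.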